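Same swap, second core: awaiting the cytotoxicity read-out

A few compounds are considered here, and "the series" means these few. Any claim that something is new, unique, unknown or untested is made for them only; others in the source may bear on it.

Compound 1 `O=c1cc(-c2ccc(Nc3ccc(F)cc3)cc2)oc2cc(O)c(O)c(O)c12` carries a (4-fluorophenyl)amino group. In a toxicity assay on Huh-7 cells (Homo sapiens) for cytotoxicity, read by CCK-8 assay, with a stated time of 24 h (on this read-out lower numbers stand for higher toxicity in this test and higher numbers for lower toxicity in this test), compound 1 gives only a limit of the assay, > 100000 nM. Compound 2 `CN1CCN(c2ccc(-c3cc(=O)c4c(O)c(O)c(O)cc4o3)cc2)CC1` differs from it by 4-methylpiperazin-1-yl in place of (4-fluorophenyl)amino on an aromatic carbon. In this assay compound 2 likewise gives a limit of the assay, > 100000 nM. That leaves a step that the two limits leave unreadable from compound 1 to compound 2; both values sit at the limit of > 100000 nM in this assay, at which 2 of the 3 values shown sit. Compound 3 `COc1cc2oc(-c3ccc(Nc4ccc(F)cc4)cc3)cc(=O)c2c(OC)c1OC` stands on a different core, and the difference between the two cores is not broken down here. In this assay, within the data shown here, compound 3 gives 77600 nM, the one value in this group that is a number rather than a limit. Compound 4 `COc1cc2oc(-c3ccc(N4CCN(C)CC4)cc3)cc(=O)c2c(OC)c1OC` has not yet been measured. Among the measured compounds shown here, it differs from compound 3 by 4-methylpiperazin-1-yl in place of (4-fluorophenyl)amino on an aromatic carbon, the same change as the one from compound 1 to compound 2. For compound 4 the expected step is a 1.3-fold higher number from compound 3 to compound 4 (0.11 log units; within the scatter). That expectation rests on compound 3 giving 77600 nM, while the measured step that the two limits leave unreadable from compound 1 to compound 2 offers no readable size to carry over. Compound 4 is accordingly estimated at 100000 nM, expected between 50000 nM and 200000 nM.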

Compound 4, half-maximal cytotoxic concentration: > 100000 nM
Compound 4 gave a limit, no number; the forecaster's own chance of this, stated with the estimate: 55%; the middle value sits exactly at the limit.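

Compound 4 gives > 100000 nM in this assay, a limit of the assay and not a number. Among these compounds, on this core, 4-methylpiperazin-1-yl in place of (4-fluorophenyl)amino therefore amounts to an at least 1.2-fold higher number from compound 3 to compound 4 (0.11 log units; that floor lies within the scatter), a floor that lies within the scatter, so the result shows only that the change brings no clear rise in toxicity in this test. The matching step on the other core cannot be read, so the two cores offer no pair of sizes to compare and it stays unproven whether the change carries over from one to the other, with most values here being limits: the limit of > 100000 nM in this assay, at which 3 of the 4 values shown sit.

The compounds shown leave open whether another group at the same place, such as morpholin-4-yl, a primary amine or a carboxylic acid, would give a number rather than a limit in this assay. They also leave open how large the effect of this change would be on either core, if it could be read as a number at both ends.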